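This account rests on a few compounds, and the source may have more. Where it says the series, first, only, none or still open, it means among the compounds named here.

Notes on the series in an assay for inhibition of alpha-N-acetylgalactosaminidase (Gallus gallus), tested at 1000 uM; a lower number here means less inhibition, a higher number more inhibition at the concentration tested (going by the name of the read-out).

Compound 1, `O=C(O)[C@H]1NC[C@H](O)[C@@H](O)[C@H]1O`, gives 31% in this assay. Compound 2, `O=C(O)[C@H]1NC[C@@H](O)[C@H](O)[C@@H]1O`, gives 11% in this assay. Going by the values given here, on these numbers compound 2 stands lowest of the two, with compound 1 as its only neighbour; the step is a number 20 percentage points lower from compound 1 to compound 2 (beyond the scatter). The step rests on nothing but (the fact that compounds 1 and 2 differ only in the configuration as drawn), so within the series a change of configuration alone has already moved the read-out by a modest amount.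

Compound 3, `O=C(O)[C@@H]1NC[C@@H](O)[C@@H](O)[C@@H]1O`, is not yet measured in this assay. Against compound 2 the change is the two compounds have the same atoms and bonds and differ only in configuration as drawn: 2 of 4 stereo elements differ; a stereocentre at a saturated ring carbon is drawn S in compound 2 and R in compound 3; a stereocentre at a saturated ring carbon is drawn S in compound 2 and R in compound 3. Among the compounds with values here, the only step that bears on this is the one from compound 1 to compound 2, which was also a change of configuration only and was modest; the direction that such a change takes cannot be read from a single step, so either direction is possible and a shift of similar size, or none beyond the scatter, is expected. For compound 3 the estimate in this assay is 20%, within 5% to 45%. This estimate means a step of a number 9 percentage points higher from compound 2 to compound 3 (within the scatter), expected to stay within or just beyond the scatter.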

Compound 3, a percentage reported as inhibition, at one concentration (the size of the read-out at that concentration, not a potency): 7.2%
For compound 3 the middle estimate is 12.8 percentage points above the measured one, and the stated range covers the measured number.
By their numbers in this assay, from the lowest: compounds 3 and 2 (each within the scatter of the next); then compound 1.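

In this assay, the new result adds a second kind of outcome for a change of configuration alone. The step is a number 3.8 percentage points lower from compound 2 to compound 3 (within the scatter), so the two stereocentres that differ in this pair leave no change that can be told from the scatter, while the wider comparison is a number 23.8 percentage points lower from compound 1 to compound 3 (beyond the scatter), of the same modest order as the earlier step from compound 1 to compound 2. Compound 1 now stands apart from both other compounds, with steps beyond the scatter to each, while compound 2 and compound 3 cannot be told apart at the single concentration tested; configuration alone is all that separates any of these compounds: the fact that compounds 1 and 3 differ only in the configuration as drawn

Every pair shown differs at more than one stereocentre, so which single stereocentre accounts for the gap to compound 1 remains open, as does whether any stereocentre matters on its own. Also open, on these data alone, is how the read-out would respond with an amide or a hydroxymethyl group in place of the carboxylic acid on the shared core.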